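The source may report more compounds than this note shows. Statements on the series, on what has been measured and on what is new or still open speak of the compounds shown alone.

Measured in a functional assay on HepG2 cells (Homo sapiens) for antiproliferative activity, read by sulforhodamine B assay, with a stated time of 48 h; on this read-out lower numbers stand for stronger inhibition and higher numbers for weaker inhibition:
- compound 1 (`COc1cccc(/C=C/C(=O)/C=C(O)/C=C/c2cccc(OC)c2OC)c1OC`): 12900 nM
- compound 2 (`COc1ccc(OC)c(/C=C/C(=O)/C=C(O)/C=C/c2cc(OC)ccc2OC)c1`): 5560 nM
- compound 3 (`COc1cc(C=C(C(=O)/C=C/c2cccc(OC)c2OC)C(=O)/C=C/c2cccc(OC)c2OC)ccc1O`): 200 nM

Compound 3 has the lowest number of the three, and its gaps to compound 1 and compound 2 both lie beyond the usual scatter. The next compound for this assay is compound 4 (`COc1cc(OC)c(C=C(C(=O)/C=C/c2cccc(OC)c2OC)C(=O)/C=C/c2cccc(OC)c2OC)c(OC)c1`). It places 2,4,6-trimethoxyphenyl in place of 4-hydroxy-3-methoxyphenyl on a double-bonded chain carbon bound to a double-bonded chain carbon.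

Within the data shown here, no measured pair shows this exchange on its own, since compound 1 and compound 2 differ from compound 3 in more than one place. The size of the step is therefore a judgement with little support. The rest of compound 4 matches compound 3, so the value of compound 3 at 200 nM serves as the anchor. A moderate rise in the number is expected, probably somewhat beyond the scatter, though no change beyond the scatter cannot be excluded. The estimated move is a 2.8-fold higher number from compound 3 to compound 4 (0.44 log units; beyond the scatter). The expected value for compound 4 is 550 nM, with an estimated range of 130 nM to 2500 nM.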

Compound 4, half-maximal inhibitory concentration: 300 nM
The estimate for compound 4 lay 1.8-fold (0.26 log units) above the measured number; low and high end bracket the measured number.
By their numbers in this assay, from the lowest: compounds 3 and 4 (each within the scatter of the next); then compound 2; then compound 1.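

In this assay, among these compounds, the step of a 1.5-fold higher number from compound 3 to compound 4 (0.18 log units; within the scatter) is the first single exchange that can be read, since compound 1 and compound 2 each differ from compound 3 in more than one place. At this position, on a double-bonded chain carbon bound to a double-bonded chain carbon, 2,4,6-trimethoxyphenyl can stand in place of 4-hydroxy-3-methoxyphenyl with no change beyond the scatter, although the entering group has 0 hydrogen-bond donors against 1 in the leaving group and is larger, with 12 heavy atoms against 9; for this pair, then, the hydroxyl group is not needed to keep the number in this range. No accompanying measurement offers an explanation for how closely the two compounds read.

From the compounds shown here alone, whether the same holds for a group of a different kind at this position, such as an unsubstituted phenyl or a phenyl carrying an amine or a carboxylic acid, remains open. Also open, going by these compounds, is whether the result carries over to another core, as this single pair shares one background.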